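A few compounds are considered here, and "the series" means these few. Any claim that something is new, unique, unknown or untested is made for them only; others in the source may bear on it.

Values in a physicochemical assay for lipophilicity (on this read-out higher numbers stand for higher lipophilicity and lower numbers for lower lipophilicity), for the three measured compounds:

Compound 1, `C[C@H]1CC[C@@H]2[C@@H](OC(=O)[C@]23CC(c2ccccc2)=NO3)[C@]2(C)C(=O)C=C[C@@]12O`, gives 1.41.
Compound 2, `Cc1cccc(C2=NO[C@]3(C2)C(=O)O[C@@H]2[C@H]3CC[C@H](C)[C@]3(O)C=CC(=O)[C@@]23C)c1`, gives 1.86.
Compound 3, `Cc1ccccc1C1C[C@@]2(ON1c1ccccc1)C(=O)O[C@@H]1[C@H]2CC[C@H](C)[C@]2(O)C=CC(=O)[C@@]12C`, gives 3.64.

Compound 3 stands highest of the three in this assay; the nearest of the others is compound 2, and compound 1 is furthest away. How the core of compound 3 differs from that of compound 2 is not broken down here.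

For the measured compounds named here, the one step that can be read within this set runs from compound 2 to compound 1. The change is hydrogen in place of methyl on an aromatic carbon and it gave a number 0.45 log units lower from compound 2 to compound 1 (beyond the scatter).

Compound 4, `C[C@H]1CC[C@@H]2[C@@H](OC(=O)[C@]23CC(c2ccccc2)N(c2ccccc2)O3)[C@]2(C)C(=O)C=C[C@@]12O`, is not yet measured in this assay. It is reached from compound 3 by hydrogen in place of methyl on an aromatic carbon. Going by the values given here, this is the same kind of change as the one from compound 2 to compound 1, not the same one: in compound 2 the methyl sits meta to a large group, in compound 3 it sits ortho to a large group, and the cores carrying the ring differ in a way that is not broken down here.

Among the compounds with values here, with only one earlier step of this kind to rest on, the step from compound 3 to compound 4 is expected to be of similar size, a number 0.44 log units lower from compound 3 to compound 4 (beyond the scatter), because compound 2 to compound 1 gave a number 0.45 log units lower from compound 2 to compound 1 (beyond the scatter). On that basis compound 4 is estimated at 3.2 in this assay, with a likely range from 2.8 to 3.6.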

Compound 4, partition coefficient: 3.19
Compound 4: middle estimate off by 0.01 log units, on the high side; the measured number falls inside the stated range.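

In this assay, the change from 2-methylphenyl to phenyl gave a number 0.45 log units lower from compound 3 to compound 4 (beyond the scatter), and the same kind of change on the other core gave a number 0.45 log units lower from compound 2 to compound 1 (beyond the scatter), so the two steps read alike on these two cores, even though the methyl in compound 3 sits ortho to a large group and the methyl in compound 2 does not. This supports carrying the methyl-to-hydrogen step between these two cores as a working estimate, but two pairs do not show that it holds on any further core or at every place on the ring, and the difference in overall level between the two cores remains a separate matter that neither step addresses. Nothing available here bears on why the two steps match.

The compounds shown leave open whether other groups on this aromatic ring, such as an ethyl group, a methoxy group, an amine or a carboxylic acid, would give steps that carry from one core to the other in the same way. For the compounds shown here, they also leave open how this assay would respond to any such group on the second phenyl ring, the one shared by compound 3 and compound 4.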